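Changing the Ring on the Sulfonyl Sulfur: Compound 4

The compounds below may be only part of what the source reports. "The series", "measured", "known", "first", "only" and "open" are said of these compounds alone.

Compound 1 `COc1ccc(S(=O)(=O)c2cnc3cc(F)ccc3c2-c2ccc(Cl)cc2)cc1` gives the lowest number of the three measured compounds in an ADME assay on microsomes from liver (Homo sapiens) for metabolic stability, tested at 2.5 uM (on this read-out lower numbers stand for slow clearance and higher numbers for fast clearance), with 1.28 mL/min. Compound 3 `COc1ccc(S(=O)(=O)c2cnc3cc(F)ccc3c2-c2ccc(F)cc2)cc1` gives 1.71 mL/min, and compound 2 `COc1ccc(S(=O)(=O)c2cnc3cc(F)ccc3c2-c2cccc(F)c2)cc1` gives 2.94 mL/min. The step of a 1.3-fold higher number from compound 1 to compound 3 (0.13 log units; within the scatter) stays within the scatter, while the step of a 2.3-fold higher number from compound 1 to compound 2 (0.36 log units; beyond the scatter) is a modest one beyond it. Compound 4 `Cc1ccc(S(=O)(=O)c2cnc3cc(F)ccc3c2-c2ccc(Cl)cc2)cc1C` differs from compound 1 in one place: 3,4-dimethylphenyl in place of 4-methoxyphenyl on a sulfonyl sulfur. Within the data shown here, none of the measured steps changes the group on the sulfonyl sulfur; each of them alters a different ring, so no direct guide exists for this change. With nothing to point either way, the expectation is a step of a 1.4-fold higher number from compound 1 to compound 4 (0.15 log units; within the scatter) that stays within the scatter. Compound 4 is therefore estimated at 1.8 mL/min, in the range 0.9 mL/min to 3.6 mL/min.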

Compound 4, intrinsic clearance in a liver preparation (reported as CLH), per the amount of preparation that the assay uses: 7.88 mL/min
Compound 4: middle estimate off by 4.4-fold (0.64 log units), on the low side, outside the stated range (above it).
By their numbers in this assay, from the lowest: compounds 1, 3 and 2 (each within the scatter of the next, the first and the last beyond it); then compound 4.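

Putting 3,4-dimethylphenyl in place of 4-methoxyphenyl on the sulfonyl sulfur gives a 6.2-fold higher number from compound 1 to compound 4 (0.79 log units; beyond the scatter) and so points to faster clearance, a larger step than any among compound 1, compound 2 and compound 3. The ring on the sulfonyl sulfur is therefore a place where clearance can move, at least in this pair. Nothing measured here explains the rise.

As far as these compounds go, whether 4-methylphenyl or 3,4-dimethoxyphenyl on the sulfonyl sulfur would give a number close to compound 1 remains open. So does whether 3,4-dimethylphenyl would give a similar rise with the fluorophenyl rings of compound 2 and compound 3.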